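The source may report more compounds than this note shows. Statements on the series, on what has been measured and on what is new or still open speak of the compounds shown alone.

Compound 1 `C#CCOc1ccc(C(=O)Nc2cccc(C)n2)cc1` in an in vitro assay on HEK-tsA201 cells for antagonist activity at Neuronal acetylcholine receptor; alpha3/beta4 (Homo sapiens), read by fluorescence and calcium flux; on this read-out lower numbers stand for stronger inhibition and higher numbers for weaker inhibition: compound 1 gives 21700 nM
Compound 2 `C=CCOc1ccc(C(=O)Nc2cccc(CC)n2)cc1`: compound 2 gives 27400 nM
Compound 3 `CCCOc1ccc(C(=O)Nc2cccc(CC)n2)cc1`: compound 3 gives 29200 nM

All three measured compounds share one core and give numbers that sit close together. Compound 3 stands among them, not apart from them: its gap to compound 2 and its gap to compound 1 both fall within the usual scatter of repeated measurements, so no ranking among the three can be read from these numbers.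

Compound 4 `CCCCCNc1cccc(NC(=O)c2ccc(OCCC)cc2)n1` has not yet been measured in this assay. Its difference from compound 3 is pentylamino in place of ethyl on an aromatic carbon. This change sits on the aromatic carbon of the six-membered aromatic ring with 1 nitrogen, next to the ring nitrogen, meta to a large group.

Going by the values given here, the only measured step, a 1.1-fold higher number from compound 2 to compound 3 (0.03 log units; within the scatter), concerns the chain bound to the oxygen on the other aromatic ring, not the ring that carries the change here. It therefore says little about this step beyond showing that a small change on the core left the number where it was. Among the compounds with values here, no measured step tests a change on the nitrogen-containing ring, so the direction of this step is open.

Compound 4 is expected to land near compound 3, as a 1.5-fold lower number from compound 3 to compound 4 (0.16 log units; within the scatter), with wide uncertainty. The estimate for compound 4 is 20000 nM, from 4000 nM to 80000 nM.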

Compound 4, half-maximal inhibitory concentration: > 100000 nM
Compound 4: only a limit was reported; the forecaster's own chance of this, stated with the estimate: 20%; at least 5.0-fold (0.69 log units) between middle value and limit.
By their numbers in this assay, from the lowest: compounds 1, 2 and 3 (each within the scatter of the next). At a limit, above all of these: compound 4.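

In this assay, going by these compounds alone, replacing ethyl with pentylamino on the aromatic carbon next to the ring nitrogen gives an at least 3.4-fold higher number from compound 3 to compound 4 (0.53 log units; beyond the scatter), the first step in this set that lies beyond the scatter. Within the data shown here, compound 4 gives > 100000 nM, which is a limit of the assay and not a number, so the step marks only the smallest gap the data allow and its true size stays unknown: the limit of > 100000 nM in this assay, at which 1 of the 4 values shown sits. The one earlier step, a 1.1-fold higher number from compound 2 to compound 3 (0.03 log units; within the scatter), changed the chain bound to the oxygen on the other aromatic ring, whereas this result shows that the number can respond to a change on the ring with the nitrogen.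

This single step swaps the ethyl for a longer chain and also brings in a nitrogen with a hydrogen-bond donor, so it cannot separate the effect of the chain length from that of the nitrogen. A plain pentyl group would test the chain without the nitrogen, while a short methylamino or a bare amine would test the nitrogen without the long chain.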